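This account rests on a few compounds, and the source may have more. Where it says the series, first, only, none or still open, it means among the compounds named here.

For the measured compounds named here, compound 1 `CCCCCOC(=O)N1CCN(C(=O)[C@H](CCC(=O)O)NC(=O)c2cc(N3CCC(C(=O)NCC)CC3)nc(-c3ccccc3)n2)CC1` stands at the top of the two numbers measured so far in an in vivo ADME assay on the whole organism (strain Sprague-Dawley) for pharmacokinetics, with Rattus norvegicus as the target; on this read-out lower numbers stand for slow clearance and higher numbers for fast clearance: compound 1 gives 8 mL/min/kg, while compound 2 `CCCCCOC(=O)N1CCN(C(=O)[C@H](CCC(=O)O)NC(=O)c2nc(-c3ccccc3)cc(N3CCC(COC)CC3)n2)CC1` gives 6 mL/min/kg, and the gap between these two lies within the usual scatter. Compound 3 `CCCCCOC(=O)N1CCN(C(=O)[C@H](CCC(=O)O)NC(=O)c2cc(N3CCC(CNC)CC3)nc(-c3ccccc3)n2)CC1` carries a single change from compound 1: (methylamino)methyl in place of ethylcarbamoyl on a saturated ring carbon. Going by the values given here, no measured pair shows this change, so nothing fixes its size; a small rise in clearance is expected, a 1.5-fold higher number from compound 1 to compound 3 (0.18 log units; within the scatter), possibly no more than the scatter. Compound 3 is estimated at 12 mL/min/kg, within 5 mL/min/kg to 30 mL/min/kg.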

Compound 3, clearance: 31 mL/min/kg
For compound 3 the middle estimate is 2.6-fold (0.41 log units) below the measured one; the measured number lies above the stated range.
By their numbers in this assay, from the lowest: compounds 2 and 1 (each within the scatter of the next); then compound 3.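

Replacing 4-(ethylcarbamoyl)piperidin-1-yl with 4-((methylamino)methyl)piperidin-1-yl gives a 3.9-fold higher number from compound 1 to compound 3 (0.59 log units; beyond the scatter) in this assay and so shows that a single change on this saturated ring carbon can move clearance beyond the scatter. For the compounds shown here, the two earlier compounds could not show this, as their numbers lie within the scatter and no single-change step joins them. Nothing at hand bears on the reason for the rise.

The compounds shown leave open whether the rise follows the amine or the loss of the amide. A hydroxymethyl or a dimethylaminomethyl group on the same ring carbon would help separate the two.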